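The compounds below may be only part of what the source reports. "The series", "measured", "known", "first", "only" and "open" are said of these compounds alone.

Measured compounds, binding affinity to the 5-hydroxytryptamine receptor 1D:

compound 1 `NC(=O)c1ccc2c(c1)CCOC2CCN1CC=C(c2c[nH]c3cc(C(F)(F)F)ccc23)CC1` gives 122 nM
compound 2 `NC(=O)c1ccc2c(c1)CCOC2CCN1CC=C(c2c[nH]c3c(Cl)c(Cl)ccc23)CC1` gives 165 nM
compound 3 `NC(=O)c1ccc2c(c1)CCOC2CCN1CC=C(c2c[nH]c3ccc(F)cc23)CC1` gives 130 nM

All three numbers come from an assay on cells for binding affinity to 5-hydroxytryptamine receptor 1D (Homo sapiens), read by radioligand binding; on this read-out lower numbers stand for stronger inhibition and higher numbers for weaker inhibition. Compound 3 stands second highest of the three, but its nearest neighbour is compound 1 and its furthest is compound 2, and both gaps lie within the scatter of repeated measurements, so the three compounds cannot be told apart on these data. The shared core of compound 3 carries a trifluoromethyl group in compound 1 and two chlorines in compound 2, and neither variation moves the number beyond the scatter.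

The next compound is compound 4 `NC(=O)c1ccc2c(c1)CCOC2CCN1CC=C(c2[nH]nc3cc(F)ccc23)CC1`. It differs from compound 3 in one place: 6-fluoro-2H-indazol-3-yl in place of 5-fluoro-1H-indol-3-yl on a double-bonded ring carbon. For the measured compounds named here, no step of this kind, an indole replaced by an indazole on the double-bonded ring carbon, has been measured, so no directly comparable step is available.

Given that the three measured variations on the bicyclic group all stay within the scatter of each other, the step from compound 3 to compound 4 is expected to be modest as well, a 1.4-fold higher number from compound 3 to compound 4 (0.14 log units; within the scatter), with a slight lean toward a higher number. The estimate for compound 4 in this assay is 180 nM, with the expected range running from 60 nM to 550 nM.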

Compound 4, inhibition constant: 24 nM
Compound 4: middle estimate off by 7.5-fold (0.88 log units), on the high side; measured number below the stated range.
By their numbers in this assay, from the lowest: compound 4; then compounds 1, 3 and 2 (each within the scatter of the next).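

In this assay, replacing the bicyclic group at the double-bonded ring carbon gives a 5.4-fold lower number from compound 3 to compound 4 (0.73 log units; beyond the scatter), so this position is not as indifferent to the bicyclic group as the close values of compounds 1, 2 and 3 suggested. The step combines more than one difference: a ring carbon gives way to a nitrogen, the group gains a hydrogen-bond acceptor, and the fluorine changes from the 5-fluoro of the indole name to the 6-fluoro of the indazole name, so the effects of these differences cannot be separated. No supporting measurement bears on why this change lowers the number.

A 5-fluoro-2H-indazol-3-yl or a 6-fluoro-1H-indol-3-yl group would help separate the contribution of the ring nitrogen from that of the fluorine's place. Also open, on these data alone, is whether the step carries over to other groups on the indazole, such as a trifluoromethyl or two chlorines, the groups seen on the indoles of compounds 1 and 2, or to an unsubstituted 2H-indazol-3-yl.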